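Swapping the aryl group on an inactive triazole

A few compounds are considered here, and "the series" means these few. Any claim that something is new, unique, unknown or untested is made for them only; others in the source may bear on it.

Compound 2 `O=C1O/C(=C\Cn2cc(-c3ccc(Br)cc3)nn2)C(OCc2ccccc2)=C1OCc1ccccc1` belongs to a small set tested in a functional assay on A549 cells (Homo sapiens) for antiproliferative activity, read by MTT assay, with a stated time of 72 h; a lower number here means a stronger inhibitor, a higher number a weaker inhibitor. In this assay compound 2 gives > 100000 nM, which is a limit of the assay rather than a number. Its near relative compound 1 `Cc1ccc(-c2cn(C/C=C3\OC(=O)C(OCc4ccccc4)=C3OCc3ccccc3)nn2)cc1` gives > 100000 nM in this assay, again only a limit. The step that the two limits leave unreadable from compound 1 to compound 2 therefore cannot be read in size. Only compound 3 `Cc1ccc(-c2cn(C[C@H](O)[C@H]3OC(=O)C(OCc4ccccc4)=C3OCc3ccccc3)nn2)cc1`, which carries a different link between the triazole and the shared core, returns a number, 8690 nM in this assay.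

Compound 4 `COc1ccccc1-c1cn(C/C=C2\OC(=O)C(OCc3ccccc3)=C2OCc2ccccc2)nn1` is the next member. Relative to compound 2 the change is 2-methoxyphenyl in place of 4-bromophenyl on an aromatic carbon. Among the compounds with values here, no measured step follows a change of this kind, so none can be used to predict its effect. What the data do show is the limit of > 100000 nM in this assay, at which 2 of the 3 values shown sit, and compound 4 keeps the same link and core as compound 1 and compound 2. The step that the limit leaves unreadable from compound 2 to compound 4 is therefore expected to stay within the scatter, with no gain in potency. For compound 4 an activity of about 120000 nM is expected, in the range 30000 nM to 500000 nM, with a strong chance that only a limit is reported.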

Compound 4, half-maximal inhibitory concentration: > 100000 nM
Compound 4 was reported as a limit (the forecaster's own chance of this, stated with the estimate: 80%); the middle value lies beyond the limit too.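

Compound 4 is again reported only as a limit, so the steps to it from compound 1 and compound 2 cannot be read in size: the limit of > 100000 nM in this assay, at which 3 of the 4 values shown sit.

The compounds shown leave open whether 4-bromophenyl or 2-methoxyphenyl would give a measurable value if carried on the link found in compound 3.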